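From 4-methoxyphenyl to 3-fluorophenyl on a shared core

The source may hold more compounds than are shown below. What is called first, only, known or untested is meant among the compounds shown, and "the series" means these compounds.

In a functional assay on MDA-MB-231 cells (Homo sapiens) for antiproliferative activity, read by MTT assay, with a stated time of 48 h (on this read-out lower numbers stand for stronger inhibition and higher numbers for weaker inhibition), compound 3 `COC(=O)/C(=C/c1ccccc1)CN1C(=O)[C@@H](OC)[C@H]1c1ccc(OC)cc1` gives 14000 nM and sits within the usual scatter of compound 1 `COC(=O)/C(=C/c1ccccc1)CN1C(=O)[C@@H](OC)[C@H]1c1ccccc1C(F)(F)F` at 17600 nM on this measure. For compound 2 `COC(=O)/C(=C/c1ccccc1)CN1C(=O)[C@@H](OC)[C@H]1c1cccc(Cl)c1` there is no result reported. Compound 4 `COC(=O)/C(=C/c1ccccc1)CN1C(=O)[C@@H](OC)[C@H]1c1cccc(F)c1` keeps the shared core but carries 3-fluorophenyl in place of 4-methoxyphenyl on a saturated ring carbon. Going by the values given here, the one measured step at that carbon is a 1.3-fold lower number from compound 1 to compound 3 (0.10 log units; within the scatter) and it stays within the scatter. One small step is thin evidence, but it gives no reason to expect a change beyond the scatter in this assay for this swap. The expected size is a 1.1-fold higher number from compound 3 to compound 4 (0.03 log units; within the scatter) and nothing larger than the scatter. Compound 4 is expected to give 15000 nM (estimated range 7000 nM to 32000 nM).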

Compound 4, half-maximal inhibitory concentration: 34400 nM
The estimate for compound 4 lay 2.3-fold (0.36 log units) below the measured number, outside the stated range (above it).
By their numbers in this assay, from the lowest: compounds 3, 1 and 4 (each within the scatter of the next, the first and the last beyond it).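

In this assay, this saturated ring carbon now shows its first step beyond the scatter, though a modest one: a 2.5-fold higher number from compound 3 to compound 4 (0.39 log units; beyond the scatter). The other new step, a 2.0-fold higher number from compound 1 to compound 4 (0.29 log units; within the scatter), stays within the scatter, so the swap of aryl groups clearly separates compound 4 only from compound 3. No measurement on hand explains this shift. The compounds shown leave open whether losing the methoxy group or gaining the fluorine matters more, a question that an unsubstituted phenyl could help to settle. On these data alone, how a phenyl carrying an amine or a carboxylic acid would behave on this carbon also remains open.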